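Adding One Fluoro to Compound 2

This account rests on a few compounds, and the source may have more. Where it says the series, first, only, none or still open, it means among the compounds named here.

Within the data shown here, only two compounds have been measured so far in a physicochemical assay for solubility, in phosphate buffer, at pH 7.4; a higher number here means a more soluble compound, a lower number a less soluble compound. Compound 1 (`CC(=O)N[C@@H]1CCC[C@H](C(=O)Nc2cc(-c3cnn4c3CCCC4)c(F)cn2)C1`) reads > 1000000 nM, which is a limit of the assay and not a number. Among the measured compounds shown here, compound 2 (`CC(=O)N[C@@H]1CCC[C@H](C(=O)Nc2cc(-c3cnn4c3CC(C)(C)CC4)ccn2)C1`) gives 640000 nM, the only actual number available.

Compound 3 (`CC(=O)N[C@@H]1CCC[C@H](C(=O)Nc2cc(-c3cnn4c3CC(C)(C)CC4)c(F)cn2)C1`) is compound 2 with fluoro in place of hydrogen on an aromatic carbon of a six-membered aromatic ring with 1 nitrogen. The new atom sits ortho to a large group, two atoms from the ring nitrogen and para to a large group (fluoro in place of hydrogen on an aromatic carbon).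

For the measured compounds named here, no measured step isolates this swap, so compound 2 at 640000 nM is the only anchor, and no change beyond the scatter is expected. The estimated step is a 1.2-fold lower number from compound 2 to compound 3 (0.07 log units; within the scatter). The expected value for compound 3 is 550000 nM, with an estimated range of 250000 nM to 1000000 nM.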

Compound 3, solubility: 160000 nM
Compound 3: the middle estimate sits 3.4-fold (0.54 log units) above what was measured, outside the stated range (below it).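

In this assay, among these compounds, this is the first measured swap at this carbon of the aromatic ring, and fluoro in place of hydrogen gives a 4.0-fold lower number from compound 2 to compound 3 (0.60 log units; beyond the scatter). A single added fluorine atom, ortho to a large group and two atoms from the ring nitrogen, is therefore enough in this pair to move the number beyond the usual scatter. Compound 1 carries the same fluoro on a different core, but the size of any gap between it and compound 3 cannot be read, because one end of that comparison is a limit of the assay and not a number: the limit of > 1000000 nM in this assay, at which 1 of the 3 values shown sits.

As far as these compounds go, it remains open whether a chloro, a methyl or an amine at this carbon would lower the number as far as fluoro does. One pair also cannot show whether this step holds on other cores.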